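Extending a Chain on an Aromatic Nitrogen in Compound 1

The source may report more compounds than this note shows. Statements on the series, on what has been measured and on what is new or still open speak of the compounds shown alone.

Compound 1 `CN(C)C(=O)CN1CCC(c2cc3c(-c4ccc(=O)n(C)c4)ccnc3[nH]2)CC1` has been characterised in a physicochemical assay for lipophilicity, using the shake flask method, measured as octanol-water partition, at pH 7.4 (on this read-out lower numbers stand for lower lipophilicity and higher numbers for higher lipophilicity), where compound 1 gives 1.1. Among the measured compounds shown here, this is the lowest of the two numbers recorded so far; the only other measured compound, compound 2 `COc1cc(F)ccc1-c1ccnc2[nH]c(C3CCN(CC(=O)N(C)C)CC3)cc12`, gives 2.9 in this assay. For the measured compounds named here, the one measured step, a number 1.80 log units higher from compound 1 to compound 2 (beyond the scatter), arises from a ring exchange on an aromatic carbon and therefore does not concern the same part of the molecule as the change considered here.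

Compound 3 `CN(C)C(=O)CN1CCC(c2cc3c(-c4ccc(=O)n(CCC5CCOCC5)c4)ccnc3[nH]2)CC1` differs from compound 1 in one place: (oxan-4-yl)methyl in place of hydrogen on a saturated chain carbon bound to an aromatic nitrogen. Going by the values given here, no measured pair reflects this kind of chain extension, so the expectation rests on the general observation that adding a saturated ring and several carbons to a small chain tends to raise the value in this assay, usually by a clearly noticeable amount, though less than the ring exchange measured between compound 1 and compound 2. Compound 3 is therefore expected to show an increase of a number 1.20 log units higher from compound 1 to compound 3 (beyond the scatter) over compound 1. The estimate for compound 3 is 2.3, with a range from 1.6 to 3.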

Compound 3, distribution coefficient: 1.5
Beside the measured number, compound 3's estimate is 0.80 log units above it, outside the stated range (below it).
By their numbers in this assay, from the lowest: compound 1; then compound 3; then compound 2.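

In this assay, among the compounds shown here, the saturated chain carbon bound to an aromatic nitrogen accepts the (oxan-4-yl)methyl group with only a limited rise (a number 0.40 log units higher from compound 1 to compound 3 (beyond the scatter)), and this is the only reading of a change at this place, as the earlier step concerned an exchange on an aromatic carbon. That earlier step (a number 1.80 log units higher from compound 1 to compound 2 (beyond the scatter)) is clearly the larger of the two, so from compound 1 the entry of this saturated ring on its chain moves the read-out much less than the exchange on the aromatic carbon does, although the two changes lie in different parts of the molecule. Nothing at hand explains why the step at this place is as small as it is.

The compounds shown leave open whether the size of this step belongs to the oxygen-containing ring or to the chain that carries it, a question that a cyclohexylmethyl group or a plain butyl chain at the same place would address. They also leave open how the read-out would respond to a group of another kind there, such as a tertiary amine or a carboxylic acid.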